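Swapping an alkyne alcohol for a fluoropyridine: stability

The compounds below may be only part of what the source reports. "The series", "measured", "known", "first", "only" and "open" are said of these compounds alone.

Measured so far, in an ADME assay (liver) for metabolic stability, with Liver microsome (Homo sapiens) as the target, using microsomes and NADPH, with a stated time of 30 min, tested at 1 uM; a higher number here means faster removal of the compound, a lower number slower removal:
- compound 1 `Nc1ccc(S(=O)(=O)N2CCN(c3ncc(C(O)(C(F)(F)F)C(F)(F)F)cc3C#CC3CC3)CC2)cn1` gives a limit of < 14 mL.min-1.g-1.
- compound 2 `Nc1ccc(S(=O)(=O)N2CCN(c3ncc(C(O)(C(F)(F)F)C(F)(F)F)cc3C#CCO)CC2)cn1` gives a limit of < 14 mL.min-1.g-1.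
- compound 3 `CC(C)(O)C#Cc1cc(C(O)(C(F)(F)F)C(F)(F)F)cnc1N1CCN(S(=O)(=O)c2ccc(N)nc2)CC1` gives a limit of < 14 mL.min-1.g-1.

Compound 2 stands at the limit rather than at a number, and all three compounds sit there together (the limit of < 14 mL.min-1.g-1 in this assay, at which 3 of the 3 values shown sit). The unmeasured compound 4 `Nc1ccc(S(=O)(=O)N2CCN(c3ncc(C(O)(C(F)(F)F)C(F)(F)F)cc3-c3cncc(F)c3)CC2)cn1` differs from compound 2 by 5-fluoropyridin-3-yl in place of 3-hydroxyprop-1-yn-1-yl on an aromatic carbon. The steps that touch this part of the shared core, a step that the two limits leave unreadable from compound 1 to compound 2, a step that the two limits leave unreadable from compound 2 to compound 3 and a step that the two limits leave unreadable from compound 1 to compound 3, cannot be sized. Every value is a limit, so they give no direction. The step of a number no lower from compound 2 to compound 4 (the limit leaves the size open) is therefore expected to be small, with little to lean on. Compound 4 is estimated at 14 mL.min-1.g-1 in this assay, within 6 mL.min-1.g-1 to 40 mL.min-1.g-1.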

Compound 4, intrinsic clearance in microsomes: 24 mL.min-1.g-1
Compound 4: middle estimate off by 1.7-fold (0.23 log units), on the low side; low and high end bracket the measured number.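

Among the compounds shown here, with 5-fluoropyridin-3-yl at this position, compound 4 gives the only true number in this assay, and replacing each alkyne group gives an at least 1.7-fold higher number from compound 2 to compound 4 (0.23 log units; that floor lies within the scatter), an at least 1.7-fold higher number from compound 3 to compound 4 (0.23 log units; that floor lies within the scatter) and an at least 1.7-fold higher number from compound 1 to compound 4 (0.23 log units; that floor lies within the scatter). These steps are only floors, so a real rise is possible but not shown. The steps among compound 1, compound 2 and compound 3 still cannot be read: the limit of < 14 mL.min-1.g-1 in this assay, at which 3 of the 4 values shown sit.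

On these data alone, whether a phenyl ring or a pyridine without the fluorine would give a similar number stays open. So does how far the three alkyne compounds lie under their limit.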